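The compounds below may be only part of what the source reports. "The series", "measured", "known", "first", "only" and "open" are said of these compounds alone.

Compound 3 `NCCNc1cc(N2CCN(c3ccc(Cl)cc3)CC2)nc2ccccc12` is the least tolerated of the two compounds with a number: in an ADME assay on HEp-2 cells (Homo sapiens) for cytotoxicity, read by CCK-8 assay, with a stated time of 6 days (a higher number here means that more compound is tolerated, a lower number that less compound is tolerated), compound 3 gives 6600 nM, while its nearest neighbour, compound 1 `NCCNc1cc(N2CCN(c3ccccc3Cl)CC2)nc2ccccc12`, gives 20800 nM. For compound 2 `CS(=O)(=O)N1CCN(c2cc(NCCN)c3ccccc3n2)CC1` the result is a limit, > 100000 nM, rather than a number. Between the measured compounds, a 3.2-fold lower number from compound 1 to compound 3 (0.50 log units; beyond the scatter), an at least 4.8-fold higher number from compound 1 to compound 2 (0.68 log units; beyond the scatter) and an at least 15-fold lower number from compound 2 to compound 3 (1.18 log units; beyond the scatter). Compound 4 `CC(=O)N1CCN(c2cc(NCCN)c3ccccc3n2)CC1` differs from compound 3 in one place: acetyl in place of 4-chlorophenyl on an amine nitrogen in a ring. The step that bears on this change is the large one from compound 2 to compound 3, run in reverse, so a large rise in this assay is expected, with a fair chance of a limit again. Compound 4 is therefore expected to give 100000 nM, between 30000 nM and 300000 nM. That expected move is a 15-fold higher number from compound 3 to compound 4 (1.18 log units; beyond the scatter).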

Compound 4, half-maximal cytotoxic concentration: > 100000 nM
Compound 4 gave a limit, no number (the forecaster's own chance of this, stated with the estimate: 50%); the middle value lies on the limit itself.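

Replacing either chlorophenyl group with acetyl on this amine nitrogen gives, in this assay, an at least 15-fold higher number from compound 3 to compound 4 (1.18 log units; beyond the scatter) and an at least 4.8-fold higher number from compound 1 to compound 4 (0.68 log units; beyond the scatter). The earlier rise with methylsulfonyl is therefore not confined to that group: among the compounds shown, both that lack a chlorophenyl group reach the limit. The step between compound 2 and compound 4 cannot be read, because both results are limits rather than numbers: the limit of > 100000 nM in this assay, at which 2 of the 4 values shown sit.

Still open, going by these compounds, is how the shared core behaves with a plain methyl or an unsubstituted phenyl on this nitrogen. Either group might give a number rather than a limit.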